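Chloro for Fluoro on the Benzyl Arm of Compound 3

The compounds below may be only part of what the source reports. "The series", "measured", "known", "first", "only" and "open" are said of these compounds alone.

Three compounds share one core and differ at the amide nitrogen: compound 1 `CCN(Cc1ccccc1)C(=O)C1CCN(S(=O)(=O)c2ccc(C)s2)CC1`, compound 2 `CCN(C(=O)C1CCN(S(=O)(=O)c2ccc3cn[nH]c3c2)CC1)[C@H](C)c1ccccc1` and compound 3 `CCN(Cc1cccc(F)c1)C(=O)C1CCN(S(=O)(=O)c2ccc3cn[nH]c3c2)CC1`. In a functional assay on CHO cells for positive allosteric modulation of muscarinic acetylcholine receptor M5 (Homo sapiens), read by calcium flux (a higher number here means a larger maximal response, a lower number a smaller maximal response), compound 1 gives 64%, compound 2 gives 87% and compound 3 gives 89%. Compound 3 thus sits level with compound 2 and well above compound 1. Compound 4 `CCN(Cc1cccc(Cl)c1)C(=O)C1CCN(S(=O)(=O)c2ccc3cn[nH]c3c2)CC1` carries one change against compound 3: chloro in place of fluoro on an aromatic carbon. For the measured compounds named here, the only measured step, a number 2 percentage points higher from compound 2 to compound 3 (within the scatter), swaps a different group and stays within the scatter, so no measured step truly tests a halogen exchange. The swap is therefore expected to move this assay little, as a number 1 percentage points lower from compound 3 to compound 4 (within the scatter). Compound 4 is estimated at 88%, between 74% and 100%.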

Compound 4, largest response reached (reported as percent of maximum), in percent of the reference or control that the assay uses: 77%
The estimate for compound 4 lay 11 percentage points above the measured number; the range from low to high includes it.
By their numbers in this assay, from the lowest: compound 1; then compounds 4, 2 and 3 (each within the scatter of the next, the first and the last beyond it).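

In this assay, for the compounds shown here, the choice of halogen on this aromatic carbon is not neutral: chloro in place of fluoro gives a number 12 percentage points lower from compound 3 to compound 4 (beyond the scatter) and is the first step here to pass the scatter, even though only one atom changes. The comparison with the 1-phenylethyl arm is less clear, since 3-chlorobenzyl in its place gives a number 10 percentage points lower from compound 2 to compound 4 (within the scatter) and stays inside the scatter. No available evidence explains the drop from fluoro to chloro. Still open, going by these compounds, is what a bromo, a methyl, a methoxy or an amine would give on this same carbon. Also open, on these data alone, is whether the halogen exchange behaves alike on other carbons of the ring.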